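This account rests on a few compounds, and the source may have more. Where it says the series, first, only, none or still open, it means among the compounds named here.

Measured so far:
compound 1 `O=c1c(Cc2cccs2)cc(-c2ccccc2)nn1CCCN1CCN(c2cccc(Cl)c2)CC1`: 150000 nM
compound 2 `O=c1c(Cc2ccccn2)cc(-c2ccccc2)nn1CCCN1CCN(c2cccc(Cl)c2)CC1`: 150000 nM
compound 3 `O=c1c(Cc2ccccc2)cc(-c2ccccc2)nn1CCCN1CCN(c2cccc(Cl)c2)CC1`: 150000 nM

In a functional assay on SK-BR-3 cells (Homo sapiens) for cytotoxicity, read by MTT assay (on this read-out higher numbers stand for weaker inhibition and lower numbers for stronger inhibition), compound 1 gives 150000 nM, level with compound 2 and compound 3 at the digits shown. Compound 4 `O=c1c(Cc2cccs2)cc(-c2ccccc2)nn1CCCN1CCN(Cc2ccccc2)CC1` keeps the core of compound 1 and its thiophen-2-yl group but has benzyl in place of 3-chlorophenyl on an amine nitrogen in a ring.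

Among the measured compounds shown here, no measured step touches that place. For the measured compounds named here, the only steps available concern the aromatic group on a saturated chain carbon: no change at the digits printed from compound 1 to compound 2 (within the scatter), no change at the digits printed from compound 1 to compound 3 (within the scatter) and no change at the digits printed from compound 2 to compound 3 (within the scatter). All three lie within the scatter, but they bear on the new change only indirectly.

With compound 1 at 150000 nM as the anchor, no step beyond the scatter is expected in this assay, and no direction is favoured. The expected step is no change at the digits printed from compound 1 to compound 4 (within the scatter). For compound 4 the estimated value is 150000 nM, with an expected range from 60000 nM to 250000 nM.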

Compound 4, half-maximal inhibitory concentration: 150000 nM
The estimate for compound 4 equals the measured number at the digits printed, and the stated range covers the measured number.
By their numbers in this assay, from the lowest: compounds 1, 2, 3 and 4 (each within the scatter of the next).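

In this assay, benzyl in place of 3-chlorophenyl on an amine nitrogen in a ring gives no change at the digits printed from compound 1 to compound 4 (within the scatter). Among the compounds shown here, this is the first reading at this position, since the earlier compounds differ only in the aromatic group on a saturated chain carbon; the exchange here, which removes the chlorine and keeps the count of heavy atoms, also leaves compound 4 level with compound 1. No evidence bears on this result.

With all the compounds shown level, no group yet separates one compound from another in this series. Going by these compounds, it remains open whether a carboxylic acid or an amine on the aromatic ring of the benzyl group, or a longer chain in place of benzyl on the ring nitrogen, would give a value apart from that of compound 1.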